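The source may report more compounds than this note shows. Statements on the series, on what has been measured and on what is new or still open speak of the compounds shown alone.

Compound 1 `COc1cc(NC(=O)c2cnccn2)c2ncccc2c1` gives 470 nM in a functional assay on BXPC-3 cells (Homo sapiens) for inhibition, read by MTT assay, with a stated time of 72 h; a lower number here means a stronger inhibitor, a higher number a weaker inhibitor. Compound 2 `O=C(Nc1cc(Cl)cc2cccnc12)c1ncccn1` gives only a limit, > 10000 nM, in this assay. Compound 3 `COc1cc(NC(=O)c2ncccn2)c2ncccc2c1` likewise gives only a limit, > 10000 nM, in this assay and so stands at the limit of > 10000 nM in this assay, at which 2 of the 3 values shown sit. The step of an at least 21-fold higher number from compound 1 to compound 3 (1.32 log units; beyond the scatter) is the one readable move among the measured pairs; the step that the two limits leave unreadable from compound 2 to compound 3 yields no size. Compound 4 `CC(C)(C)OC(=O)NCCOc1cc(NC(=O)c2ncccn2)c2ncccc2c1` carries ((tert-butoxycarbonyl)amino)methyl in place of hydrogen on a saturated chain carbon bound to an oxygen on an aromatic ring and keeps the pyrimidin-2-yl carbonyl of compound 3. Going by the values given here, no measured step covers this chain, and both measured compounds bearing the pyrimidin-2-yl carbonyl sit at the limit, so for compound 4 a limit is again expected in this assay, with the step that the limit leaves unreadable from compound 3 to compound 4 estimated as not readable from a limit. Compound 4 is estimated at 15000 nM, in the range 4000 nM to 50000 nM.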

Compound 4, half-maximal inhibitory concentration: > 10000 nM
Compound 4 ended at the assay's limit (the forecaster's own chance of this, stated with the estimate: 75%); the middle value is on the limit's open side.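

Compound 3 and compound 4 both sit at a limit in this assay, so no step between them can be read: the limit of > 10000 nM in this assay, at which 3 of the 4 values shown sit.

The compounds shown leave open what the 2-((tert-butoxycarbonyl)amino)ethyl chain does to a compound with a readable value, such as compound 1 at 470 nM.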